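Nitro Substitution on a Cyanosulfanyl-Bearing Fused Bicyclic Core

The source may report more compounds than this note shows. Statements on the series, on what has been measured and on what is new or still open speak of the compounds shown alone.

Compound 1 `Clc1ccc(Cc2nn3c(Br)c(-c4ccccc4)nc3s2)cc1` and compound 2 `O=[N+]([O-])c1ccc(-c2nc3sc(Cc4ccc(Cl)cc4)nn3c2Br)cc1` share one core and differ by nitro in place of hydrogen on an aromatic carbon. In a functional assay on HeLa cells (Homo sapiens) for cytotoxicity, with a stated time of 72 h (a higher number here means a weaker inhibitor, a lower number a stronger inhibitor), compound 1 gives > 250000 nM, which is a limit of the assay rather than a number. Compound 2 likewise gives > 250000 nM, again a limit. The step that the two limits leave unreadable from compound 1 to compound 2 therefore remains hidden because of the limit of > 250000 nM in this assay, at which 2 of the 3 values shown sit. Compound 3 `N#CSc1c(-c2ccccc2)nc2sc(Cc3ccc(Cl)cc3)nn12` differs from compound 1 by cyanosulfanyl in place of bromo on an aromatic carbon; in this assay compound 3 gives 12000 nM, and the step of an at least 20-fold lower number from compound 1 to compound 3 (1.31 log units; beyond the scatter). Compound 4 `N#CSc1c(-c2ccc([N+](=O)[O-])cc2)nc2sc(Cc3ccc(Cl)cc3)nn12` carries the same change relative to compound 3 that compound 2 carries relative to compound 1, namely (nitro in place of hydrogen on an aromatic carbon). Since that earlier step that the two limits leave unreadable from compound 1 to compound 2 cannot be read, the expected step is a 1.3-fold higher number from compound 3 to compound 4 (0.10 log units; within the scatter), a small one with wide uncertainty. Compound 4 is accordingly estimated at 15000 nM, between 3000 nM and 90000 nM.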

Compound 4, half-maximal inhibitory concentration: 16000 nM
Beside the measured number, compound 4's estimate is 1.1-fold (0.03 log units) below it; the range from low to high includes it.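

In this assay, nitro in place of hydrogen on the cyanosulfanyl-bearing core gives a 1.3-fold higher number from compound 3 to compound 4 (0.12 log units; within the scatter). Cyanosulfanyl in place of bromo on the nitro-bearing core gives an at least 15-fold lower number from compound 2 to compound 4 (1.19 log units; beyond the scatter), so this change is large on both cores, but its exact size on each cannot be compared: the same change on two cores in this assay, an at least 20-fold lower number (1.31 log units; beyond the scatter) from compound 1 to compound 3 and an at least 15-fold lower number (1.19 log units; beyond the scatter) from compound 2 to compound 4; the limit leaves it open whether they differ. The nitro step on the bromo-bearing core also cannot be read, so the compounds do not show whether the nitro step carries from one core to the other: the limit of > 250000 nM in this assay, at which 2 of the 4 values shown sit.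

The compounds shown leave open how an amine or a carboxylic acid in place of the nitro would read. They also leave open whether the cyanosulfanyl step stays large with such groups on the phenyl ring.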